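Dimethoxyphenyl for chlorophenyl on the saturated ring carbon

The compounds below may be only part of what the source reports. "The series", "measured", "known", "first", "only" and "open" are said of these compounds alone.

In a functional assay on HepG2 cells (Homo sapiens) for antiproliferative activity, read by MTT assay, with a stated time of 24 h (a lower number here means a stronger inhibitor, a higher number a weaker inhibitor), compound 3 `Clc1ccc(C2=NN(c3ccc(-c4ccccc4)nn3)C(c3ccc(Cl)cc3)C2)cc1` gives 10000 nM, the highest of the two numbers measured. Its nearest neighbour is compound 1 `Clc1ccc(C2CC(c3ccccc3)=NN2c2ccc(-c3ccccc3)nn2)cc1`, which in this assay gives 6310 nM, and the step of a 1.6-fold higher number from compound 1 to compound 3 (0.20 log units; within the scatter) lies within the scatter. Compound 2 `COc1ccc(C2CC(c3ccccc3)=NN2c2ccc(-c3ccccc3)nn2)cc1` gives in this assay only > 100000 nM, which is a limit, (the limit of > 100000 nM in this assay, at which 1 of the 3 values shown sits).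

Compound 4 `COc1ccc(C2CC(c3ccc(Cl)cc3)=NN2c2ccc(-c3ccccc3)nn2)c(OC)c1` has not yet been measured. It differs from compound 3 by 2,4-dimethoxyphenyl in place of 4-chlorophenyl on a saturated ring carbon. The measured step that bears on this change is an at least 15-fold higher number from compound 1 to compound 2 (1.19 log units; beyond the scatter), where a methoxy replaced a chloro on the aryl group carried by the saturated ring carbon; compound 4 again carries methoxy groups on that aryl group, and one of them sits in the position the chloro occupied. A large step upward in this assay is therefore expected for compound 4, quite possibly reaching a limit as compound 2 did. Compound 4 is estimated at 100000 nM, within 30000 nM to 300000 nM. The expected step is a 10-fold higher number from compound 3 to compound 4 (1.00 log units; beyond the scatter).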

Compound 4, half-maximal inhibitory concentration: > 100000 nM
Compound 4: a limit, no number; the forecaster's own chance of this, stated with the estimate: 60%; the middle value lies on the limit itself.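

In this assay, the change to 2,4-dimethoxyphenyl gives an at least 10-fold higher number from compound 3 to compound 4 (1.00 log units; beyond the scatter). A large rise on placing methoxy on the aryl group at this saturated ring carbon, seen before as an at least 15-fold higher number from compound 1 to compound 2 (1.19 log units; beyond the scatter), therefore also appears with a 4-chlorophenyl group, not a phenyl, on the ring atom two ring bonds away. Compound 4 gives > 100000 nM, which is a limit, so compound 2 and compound 4 cannot be ranked against each other and the true size of the new step stays unknown: the limit of > 100000 nM in this assay, at which 2 of the 4 values shown sit.

The compounds shown leave open whether one methoxy group alone on this aryl group, in the position of the 2,4-dimethoxyphenyl pattern, would behave the same way. They also leave open whether the rise in this assay is specific to methoxy, or would also follow from a hydroxyl or an amine on the same ring.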